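Aryl variation at the ether of the shared core

The compounds below may be only part of what the source reports. "The series", "measured", "known", "first", "only" and "open" are said of these compounds alone.

Measured so far in a functional assay on HEK293 cells for agonist activity at G-protein coupled receptor 39 (Homo sapiens), read by scintillation proximity assay and inositol phosphate accumulation, with a stated time of 75 min, in the presence of a further agent that is not named here; on this read-out higher numbers stand for an effect only at larger amounts of compound and lower numbers for an effect already at smaller amounts:
compound 1 `Cc1nn(-c2ncnc3nc[nH]c23)c2c1C(OCc1ccccc1F)CC(=O)N2` — 4 nM
compound 2 `Cc1nn(-c2ncnc3nc[nH]c23)c2c1C(OCc1ccc(C(C)C)cc1)CC(=O)N2` — 5 nM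
compound 3 `Cc1nn(-c2ncnc3nc[nH]c23)c2c1C(OC(=O)c1ccc(F)cc1)CC(=O)N2` — 4 nM

Compound 2 gives 5 nM in this assay, and the numbers of compound 1 and compound 3 lie within the scatter of it: the steps are a 1.3-fold higher number from compound 1 to compound 2 (0.10 log units; within the scatter) and a 1.3-fold lower number from compound 2 to compound 3 (0.10 log units; within the scatter). The third pair behaves the same way, no change at the digits printed from compound 1 to compound 3 (within the scatter). Across these three compounds the group on the oxygen on a saturated carbon is changed without any effect beyond the scatter.

Compound 4 `Cc1nn(-c2ncnc3nc[nH]c23)c2c1C(OCc1cc(F)cc3c1OCOC3)CC(=O)N2` is not yet measured. Its difference from compound 2 is a group of 11 heavy atoms (8 carbon, 2 oxygen, 1 fluorine; one six-membered non-aromatic ring with 2 hetero atoms, one six-membered aromatic ring of carbon only) in place of a group of 9 heavy atoms (9 carbon; one six-membered aromatic ring of carbon only), on a saturated chain carbon bound to an oxygen on a saturated carbon. The measured steps that bear on it are those that swap the aryl group at the same place, and all three stayed within the scatter. On that basis the expected step is no change at the digits printed from compound 2 to compound 4 (within the scatter), with no change beyond the scatter in either direction. Compound 4 is estimated at 5 nM in this assay, within a range of 2 nM to 15 nM.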

Compound 4, half-maximal effective concentration: 1.5 nM
For compound 4 the middle estimate is 3.3-fold (0.52 log units) above the measured one, and the stated range ends above it.
By their numbers in this assay, from the lowest: compound 4; then compounds 1, 3 and 2 (each within the scatter of the next).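

In this assay, the group on the saturated chain carbon bound to an oxygen on a saturated carbon now gives steps beyond the scatter (a 3.3-fold lower number from compound 2 to compound 4 (0.52 log units; beyond the scatter)) and (a 2.7-fold lower number from compound 1 to compound 4 (0.43 log units; beyond the scatter)), so this position is not insensitive to every group placed there. The entering group differs from 4-isopropylphenyl in several features at once, including a six-membered non-aromatic ring with 2 hetero atoms, a fluorine and 2 hydrogen-bond acceptors against 0, and the step cannot be assigned to any one of them. No measurement shown here explains the step.

The compounds shown leave open whether the non-aromatic ring or the fluorine accounts for the step when present alone. They also leave open how an amine or a carboxylic acid on the benzyl group would read out at this position.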